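The compounds below may be only part of what the source reports. "The series", "measured", "known", "first", "only" and "open" are said of these compounds alone.

Three compounds that share one core and differ only in the length of a saturated chain have been tested in a functional assay (brain) for inhibition, with Rattus norvegicus as the target (a higher number here means a weaker inhibitor, a lower number a stronger inhibitor), so far. Compound 1 (`CCCCCCCCCCOC1=C(O)OC(C(O)CO)C1=O`) reads 13000 nM and compound 2 (`CCCCCCCCCCCOC1=C(O)OC(C(O)CO)C1=O`) reads 13000 nM while compound 3 (`CCCCCCCCCCCCOC1=C(O)OC(C(O)CO)C1=O`) reads 54000 nM as the highest number of the three, which makes it the weakest inhibitor in this small set. Compound 4 (`CCCCCCCCCCCCCCCCOC1=C(O)OC(C(O)CO)C1=O`) has not been measured yet. Its structure differs from compound 3 by butyl in place of hydrogen on a saturated chain carbon, ten or more bonds along the chain from an oxygen on an unsaturated carbon in the form of butyl in place of hydrogen on a saturated chain carbon, ten or more bonds along the chain from an oxygen on an unsaturated carbon. Three smaller changes at that same place bear on this one. Adding methyl gave no change at the digits printed from compound 1 to compound 2 (within the scatter) and adding methyl again gave a 4.2-fold higher number from compound 2 to compound 3 (0.62 log units; beyond the scatter) while adding ethyl gave a 4.2-fold higher number from compound 1 to compound 3 (0.62 log units; beyond the scatter) overall. So one lengthening did nothing and the other weakened inhibition modestly, and butyl is a larger addition than any of these. A further move towards a higher number is therefore expected, though with wide uncertainty. The estimated change is a 1.9-fold higher number from compound 3 to compound 4 (0.27 log units; within the scatter) in this assay and it rests on only these few steps. Compound 4 is expected at 100000 nM with an estimated range from 30000 nM to 350000 nM as its likely span.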

Compound 4, half-maximal inhibitory concentration: 6800 nM
Compound 4: the middle estimate sits 15-fold (1.17 log units) above what was measured, and the stated range ends above it.
By their numbers in this assay, from the lowest: compounds 4, 1 and 2 (each within the scatter of the next); then compound 3.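

In this assay, adding butyl at this saturated chain carbon gives a 7.9-fold lower number from compound 3 to compound 4 (0.90 log units; beyond the scatter) and so runs opposite to the earlier rise, which means that lengthening the chain does not move the number steadily one way across these four compounds. Set against the two shorter chains, adding pentyl gives a 1.9-fold lower number from compound 2 to compound 4 (0.28 log units; within the scatter) and adding hexyl gives a 1.9-fold lower number from compound 1 to compound 4 (0.28 log units; within the scatter) and neither step can separate the compounds it joins. Going by these compounds alone, compounds 1, 2 and 4 therefore cannot be told apart here, and compound 3 alone stands out as the weakest inhibitor of the four, so this position accepts a much longer chain than the earlier compounds could show, while chain length alone gives no simple rule.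

The compounds shown leave open how a still longer chain would read at this position, and whether a chain carrying an amine or a carboxylic acid would keep the number in the same range. No supporting measurement is available to explain the high reading of compound 3 or the return seen with compound 4.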